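Three limits and one untested side group

This account rests on a few compounds, and the source may have more. Where it says the series, first, only, none or still open, it means among the compounds named here.

Measured so far in a functional assay on RAW264.7 cells (Mus musculus) for inhibition, with stated times of 2 h and 24 h (on this read-out lower numbers stand for stronger inhibition and higher numbers for weaker inhibition), with each reading a limit of the assay:
Compound 1 `COc1ccc(/C=C2/c3cc(OC)cc(OC)c3[C@@H](c3ccccc3)[C@@H]2c2cc(OC)cc(OC)c2)cc1` gives > 200000 nM as a limit
Compound 2 `COc1ccc([C@@H]2c3c(OC)cc(OC)cc3/C(=C/c3ccc(F)cc3)[C@H]2c2cc(OC)cc(OC)c2)cc1` gives > 200000 nM as a limit
Compound 3 `COc1ccc([C@@H]2c3c(OC)cc(OC)cc3C(SCc3ccc(F)cc3)[C@H]2c2cc(OC)cc(OC)c2)cc1` gives > 200000 nM as a limit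

Compound 3 stands at > 200000 nM in this assay as a limit and not as a number. Among the compounds with values here, it shares that place with the other two compounds, so the picture so far is the limit of > 200000 nM in this assay, at which 3 of the 3 values shown sit, and no measured step exists to learn from.

Compound 4 `COc1ccc([C@@H]2c3c(OC)cc(OC)cc3C(C(O)c3ccc(Cl)cc3)[C@H]2c2cc(OC)cc(OC)c2)cc1` keeps the shared core and carries (4-chlorophenyl)(hydroxy)methyl in place of (4-fluorobenzyl)sulfanyl on a saturated ring carbon. The exchange amounts to (4-chlorophenyl)(hydroxy)methyl in place of (4-fluorobenzyl)sulfanyl on a saturated ring carbon and the rest of the molecule stays the same.

Only a small step is expected in this assay because compound 3 reads > 200000 nM as a limit. The estimated change a number no higher from compound 3 to compound 4 (the limit leaves the size open) fits that expectation. Compound 4 is expected to read 200000 nM with an estimated range from 60000 nM to 400000 nM and the assay may well report only a limit again.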

Compound 4, half-maximal inhibitory concentration: > 200000 nM
Compound 4 was reported as a limit; the forecaster's own chance of this, stated with the estimate: 75%; the middle value lies on the limit itself.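

Within the data shown here, compound 3 and compound 4 both read as limits and not as numbers, so no step between them can be read: the limit of > 200000 nM in this assay, at which 4 of the 4 values shown sit.

Still open, from the compounds shown here alone, is whether any change to the shared core gives a reading in this assay that is a number and not a limit.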